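Trifluoromethoxy in place of methylsulfonyl in compound 1

The compounds below may be only part of what the source reports. "The series", "measured", "known", "first", "only" and "open" are said of these compounds alone.

Measured in a functional assay on A549 cells (Homo sapiens) for antiproliferative activity, read by MTT assay; a higher number here means a weaker inhibitor, a lower number a stronger inhibitor:
Compound 1 `Cn1c(=O)c(=O)n(C2CCCC2)c2nc(N/N=C/c3ccc(S(C)(=O)=O)cc3)ncc21` gives 84500 nM
Compound 2 `Cc1cc(C)c(/C=N/Nc2ncc3c(n2)n(C2CCCC2)c(=O)c(=O)n3C)c(C)c1` gives 12000 nM
Compound 3 `Cn1c(=O)c(=O)n(C2CCCC2)c2nc(N/N=C/c3ccc(F)cc3F)ncc21` gives 18300 nM

Compound 1 has the highest number of the three in this assay, which makes it the weakest of them. Compound 4 `Cn1c(=O)c(=O)n(C2CCCC2)c2nc(N/N=C/c3ccc(OC(F)(F)F)cc3)ncc21` has not yet been measured. It carries trifluoromethoxy in place of methylsulfonyl on an aromatic carbon. For the measured compounds named here, no measured pair shows this exact change. The nearest evidence is two modest steps that replace the whole 4-(methylsulfonyl)phenyl group, a 7.0-fold lower number from compound 1 to compound 2 (0.85 log units; beyond the scatter) and a 4.6-fold lower number from compound 1 to compound 3 (0.66 log units; beyond the scatter). Both lie beyond the scatter and both go to a lower number, with no measured replacement going against them. The two replacements cannot be told apart, as a 1.5-fold higher number from compound 2 to compound 3 (0.18 log units; within the scatter) lies within the scatter. A modest step of similar size towards a lower number is therefore expected, though less firmly than a direct comparison would allow. The expected step is a 3.8-fold lower number from compound 1 to compound 4 (0.58 log units; beyond the scatter). For compound 4 the estimated value is 22000 nM, with an expected range of 9000 nM to 55000 nM.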

Compound 4, half-maximal inhibitory concentration: 12900 nM
The estimate for compound 4 lay 1.7-fold (0.23 log units) above the measured number, within the range that was stated.
By their numbers in this assay, from the lowest: compounds 2, 4 and 3 (each within the scatter of the next); then compound 1.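

In this assay, keeping the phenyl ring and exchanging only the methylsulfonyl on its aromatic carbon gives a 6.6-fold lower number from compound 1 to compound 4 (0.82 log units; beyond the scatter), so changing this one group is enough for a step of the size earlier seen only when the whole 4-(methylsulfonyl)phenyl group was replaced. Compound 4 lies within the scatter of compound 2 and compound 3, so these three cannot be told apart, while compound 1, the only one with methylsulfonyl, stands apart from them. Nothing available explains this step.

The compounds shown leave open whether an amine or a carboxylic acid on the same aromatic carbon would behave like methylsulfonyl or like trifluoromethoxy. As far as these compounds go, without a plain phenyl ring carrying neither group, it also stays open whether trifluoromethoxy lowers the number or methylsulfonyl raises it.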